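The compounds below may be only part of what the source reports. "The series", "measured", "known", "first", "only" and "open" are said of these compounds alone.

Compound 1 `Cc1cn([C@H]2C[C@H](N)[C@@H](CO)O2)c(=O)[nH]c1=O` gives in a functional assay on D-38 cells (Homo sapiens) for cytotoxicity (a lower number here means that less compound is needed, a higher number that more compound is needed for the effect), 100 uM.
Compound 2 `N[C@H]1C[C@H](n2ccc(=O)[nH]c2=O)O[C@@H]1CO` gives in this assay only a limit, > 100 uM.
Compound 3 `NC1CC(n2cc(Br)c(=O)[nH]c2=O)OC1CO` gives in this assay only a limit, > 100 uM.

Compound 3 therefore stands at the top edge of what this assay reports; its value is a limit, not a number, and it shares that position with compound 2, as the limit of > 100 uM in this assay, at which 2 of the 3 values shown sit, shows. Only compound 1 carries a measured number, and it sits at the same concentration as the limit. For the measured compounds named here, the one step that can be read, a number no lower from compound 1 to compound 2 (the limit leaves the size open), concerns hydrogen in place of methyl on an aromatic carbon and runs toward the limit, so its size cannot be read. Compound 2 and compound 3, differing by hydrogen against bromo, both show the limit and nothing more.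

Compound 4 `NC1CC(n2cc(F)c(=O)[nH]c2=O)OC1CO` differs from compound 3 by fluoro in place of bromo on an aromatic carbon. Going by the values given here, no measured step concerns an exchange of one halogen for another, so nothing bears directly on it; the only measured step, a number no lower from compound 1 to compound 2 (the limit leaves the size open), was at most flat toward the limit. The expected step of a number no higher from compound 3 to compound 4 (the limit leaves the size open) is accordingly none beyond the scatter. For compound 4 the estimate in this assay is 100 uM, within 40 uM to 250 uM, with a good chance that only the limit is reported again.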

Compound 4, concentration for half-maximal effect: > 100 uM
Compound 4: no number, only a limit; the forecaster's own chance of this, stated with the estimate: 65%; the middle value lies on the limit itself.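

Compound 3 and compound 4 are both reported only as limits in this assay, so no step can be read between them: the limit of > 100 uM in this assay, at which 3 of the 4 values shown sit.

The compounds shown leave open whether hydrogen, bromo and fluoro on this aromatic carbon differ at all in this assay, with compound 2, compound 3 and compound 4 all given as limits and not numbers.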